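The source may hold more compounds than are shown below. What is called first, only, known or untested is meant among the compounds shown, and "the series" means these compounds.

The measured compounds are:

compound 1, `O=C(Nc1cccc(-n2cc(-c3ccncc3)c(-c3cc(O)cc(Cl)c3)n2)c1)Nc1ccc(Cl)c(C(F)(F)F)c1`, with 97%
compound 2, `O=C(Nc1cccc(-n2cc(-c3ccncc3)c(-c3cc(O)cc(Cl)c3)n2)c1)Nc1ccc(Cl)c(Cl)c1`, with 95%
compound 3, `COc1cc(Cl)cc(-c2nn(-c3cccc(NC(=O)Nc4cc(C(F)(F)F)cc(C(F)(F)F)c4)c3)cc2-c2ccncc2)c1`, with 100%

All three numbers come from a functional assay on SK-MEL-5 cells (Homo sapiens) for inhibition, read by sulforhodamine B assay, with a stated time of 48 h, tested at 0.01 uM (on this read-out higher numbers stand for a weaker effect at the one concentration tested and lower numbers for a stronger effect), and all three lie within the usual scatter of one another, so compound 2 cannot be told apart from compound 1 or compound 3 on these data. Among the measured compounds shown here, the only measured step between compounds that differ in one place is a number 2 percentage points lower from compound 1 to compound 2 (within the scatter), which goes with chloro in place of trifluoromethyl on an aromatic carbon; it is a change at a different place from the one followed here, and it stayed within the scatter.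

Compound 4, `COc1cc(Cl)cc(-c2nn(-c3cccc(NC(=O)Nc4ccc(Cl)c(Cl)c4)c3)cc2-c2ccncc2)c1`, has not yet been measured. It differs from compound 2 by methyl in place of hydrogen on an oxygen on an aromatic ring, that is, hydroxy becoming methoxy. For the measured compounds named here, no measured step isolates this change. Going by the values given here, compound 3 already carries the methoxy group, yet it also differs from compound 2 elsewhere, so its value shows only that a methoxy-bearing compound can sit in the same high range. With every measured number close together, the expectation is a number 1 percentage points higher from compound 2 to compound 4 (within the scatter), nothing beyond the scatter. Compound 4 is therefore estimated at 96%, within a range from 88% to 100%.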

Compound 4, a percentage reported as activity, at one concentration (the size of the read-out at that concentration, not a potency): 95%
Beside the measured number, compound 4's estimate is 1 percentage points above it; the range from low to high includes it.
By their numbers in this assay, from the lowest: compounds 2, 4, 1 and 3 (each within the scatter of the next).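

Among the compounds shown here, this is the first reading that isolates hydroxy to methoxy on the 3-chloro-5-hydroxyphenyl group, since compound 3 also differs from compound 2 elsewhere. In this assay the exchange gives no change at the digits printed from compound 2 to compound 4 (within the scatter) and, with the rest of the molecule held the same, the added methyl on the oxygen produces no difference that can be told from the usual scatter of this read-out. This holds only for the one concentration tested, and no measured property of either group is available to account for the result.

The compounds shown leave open whether an amine or a carboxylic acid in place of the hydroxy group, or a longer chain such as ethoxy on the same oxygen, would read any differently. Since the read-out comes from a single concentration and is not a potency, they also leave open whether compound 2 and compound 4 would stay together at other concentrations.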